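This account rests on a few compounds, and the source may have more. Where it says the series, first, only, none or still open, it means among the compounds named here.

Of the compounds shown here, three built on one shared core have been tested in a functional assay on MOLT-4 cells (Homo sapiens) for antiproliferative activity; a higher number here means a weaker inhibitor, a lower number a stronger inhibitor. Compound 1 `COc1cc(C(=O)c2sc(-c3ccc(C)cc3)cc2N)cc(OC)c1OC` gives 16 nM. Compound 2 `COc1cc(C(=O)c2sc(-c3cccs3)cc2N)cc(OC)c1OC` gives 8.9 nM, and the step of a 1.8-fold lower number from compound 1 to compound 2 (0.25 log units; within the scatter) lies within the scatter. Compound 3 `COc1cc(C(=O)c2sc(-c3ccc(Cl)cc3)cc2N)cc(OC)c1OC` gives 77 nM, the highest of the three numbers, so it is the weakest of the set: the steps of a 4.8-fold higher number from compound 1 to compound 3 (0.68 log units; beyond the scatter) and an 8.7-fold higher number from compound 2 to compound 3 (0.94 log units; beyond the scatter) both lie beyond the scatter.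

Compound 4 `COc1cc(C(=O)c2sc(-c3ccc(Cl)c(Cl)c3)cc2N)cc(OC)c1OC` differs from compound 3 by chloro in place of hydrogen on an aromatic carbon. For the measured compounds named here, no measured step adds a chloro group to a ring that already carries one. The step that comes closest is a 4.8-fold higher number from compound 1 to compound 3 (0.68 log units; beyond the scatter), where a chloro group entered for a methyl and the number rose; the step of an 8.7-fold higher number from compound 2 to compound 3 (0.94 log units; beyond the scatter) points the same way. The number for compound 4 is therefore expected near or somewhat above that of compound 3 rather than below it. For compound 4 the expected step is a 1.9-fold higher number from compound 3 to compound 4 (0.29 log units; within the scatter). Compound 4 is estimated at 150 nM, in a range from 50 nM to 450 nM.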

Compound 4, half-maximal inhibitory concentration: 270 nM
Compound 4: middle estimate off by 1.8-fold (0.26 log units), on the low side; the measured number falls inside the stated range.
By their numbers in this assay, from the lowest: compounds 2 and 1 (each within the scatter of the next); then compound 3; then compound 4.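

Adding a second chloro group to the phenyl ring, ortho to the chloro group already there, makes a clear difference of its own: in this assay the change from 4-chlorophenyl to 3,4-dichlorophenyl gives (a 3.5-fold higher number from compound 3 to compound 4 (0.54 log units; beyond the scatter)). Replacing the other aryl groups gives much larger steps, with (a 17-fold higher number from compound 1 to compound 4 (1.23 log units; beyond the scatter)) from 4-methylphenyl and (a 30-fold higher number from compound 2 to compound 4 (1.48 log units; beyond the scatter)) from thiophen-2-yl, so the group at this position can move the number over a wide range. Nothing measured here gives a reason for these rises.

From the compounds shown here alone, whether a fluoro group, a methoxy group or an amine in place of the added chloro group would also raise the number remains open. So does whether the rise is specific to chloro or follows any group entering at this ring carbon.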